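The compounds below may be only part of what the source reports. "The series", "measured", "known", "first", "only" and "open" are said of these compounds alone.

Measured so far:
compound 1, `Cc1ccccc1NS(=O)(=O)c1ccc(N2CCNC2=O)cc1`, 200 nM
compound 2, `O=C1NCCN1c1ccc(S(=O)(=O)Nc2ccc(OC(F)F)cc2)cc1`, 650 nM
compound 3, `Cc1ccc(NS(=O)(=O)c2ccc(N3CCNC3=O)cc2)c(C)c1`, 180 nM

All three share the same core and differ only in the aryl group on the sulfonamide nitrogen. In a functional assay on HT-29 cells (Homo sapiens) for antiproliferative activity, read by sulforhodamine B assay, with a stated time of 48 h (on this read-out lower numbers stand for stronger inhibition and higher numbers for weaker inhibition), compound 1 sits second highest of the three numbers; compound 3 is its nearest neighbour, with a 1.1-fold lower number from compound 1 to compound 3 (0.05 log units; within the scatter), while compound 2 gives the highest number of the three, and the gap between compound 1 and compound 2 lies beyond the scatter.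

Compound 4, `O=C1NCCN1c1ccc(S(=O)(=O)Nc2ccc(F)cc2)cc1`, has not yet been measured. It differs from compound 1 as follows: 4-fluorophenyl in place of 2-methylphenyl on a sulfonamide nitrogen. Among the compounds with values here, no measured step covers exactly this change. Within the data shown here, the one step that is known, from compound 1 to compound 3, adds a methyl and is within the scatter, so it says little here. The values of compound 1 and compound 2 show that an aryl group carrying only a substituent at the position named in "4-fluorophenyl" gave a higher number than the 2-methylphenyl group. On that basis a modest weakening is expected for compound 4, with a 2.3-fold higher number from compound 1 to compound 4 (0.35 log units; beyond the scatter). Compound 4 is therefore estimated at 450 nM, in the range 180 nM to 1200 nM.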

Compound 4, half-maximal inhibitory concentration: 370 nM
Compound 4: the middle estimate sits 1.2-fold (0.09 log units) above what was measured; low and high end bracket the measured number.
By their numbers in this assay, from the lowest: compounds 3, 1, 4 and 2 (each within the scatter of the next, the first and the last beyond it).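

In this assay, the step of a 1.9-fold higher number from compound 1 to compound 4 (0.27 log units; within the scatter) stays within the scatter, so at this sulfonamide nitrogen the 4-fluorophenyl and 2-methylphenyl groups cannot be told apart. Within the data shown here, the step of a 2.1-fold higher number from compound 3 to compound 4 (0.31 log units; beyond the scatter) does pass the scatter, but only modestly, so the 2,4-dimethylphenyl group is the only one of these neighbours that compound 4 separates from in this direction. On the other side, fluoro in place of difluoromethoxy gives a 1.8-fold lower number from compound 2 to compound 4 (0.24 log units; within the scatter) and stays within the scatter, so compound 4 sits in an overlapping middle, not clearly apart from compound 1 or compound 2.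

No measured property is available to account for these small steps. On these data alone, whether an amine or a carboxylic acid on the aryl group would shift the number much further stays open.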